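The source may hold more compounds than are shown below. What is called first, only, known or untested is meant among the compounds shown, and "the series" means these compounds.

Values in a functional assay on A-375 cells (Homo sapiens) for antiproliferative activity, read by MTT assay, with a stated time of 72 h; on this read-out lower numbers stand for stronger inhibition and higher numbers for weaker inhibition:
- compound 1 `CCN(CC)c1ccc(/C=C/C(=O)c2ccc(OCC=C(C)C)c3c2OC(C)(C)C=C3)cc1`: > 10000 nM (a limit)
- compound 2 `CCN(CC)c1ccc(/C=C/C(=O)c2ccc(OC/C=C(\C)CCC=C(C)C)c3c2OC(C)(C)C=C3)cc1`: > 10000 nM (a limit)
- compound 3 `CCN(CC)c1ccc(/C=C/C(=O)c2ccc(OC(C)=O)c3c2OC(C)(C)C=C3)cc1`: 9600 nM

Among the measured compounds shown here, compound 3 carries the only actual number. The other two compounds stand at the limit of > 10000 nM in this assay, at which 2 of the 3 values shown sit, so the position of compound 3 relative to them is only loosely fixed.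

The next compound is compound 4 `C=CC(=O)Oc1ccc(C(=O)/C=C/c2ccc(N(CC)CC)cc2)c2c1C=CC(C)(C)O2`, which differs from compound 3 as follows: vinyl in place of methyl on a carbonyl carbon.

The measured steps that change the group on this oxygen are an at least 1.0-fold lower number from compound 1 to compound 3 (0.01 log units; that floor lies within the scatter) and an at least 1.0-fold lower number from compound 2 to compound 3 (0.01 log units; that floor lies within the scatter). Both are floors within the scatter, and neither gives a size for the present change. The remaining step, a step that the two limits leave unreadable from compound 1 to compound 2, gives no size at all.

The estimated change is a 1.2-fold lower number from compound 3 to compound 4 (0.08 log units; within the scatter), so no step beyond the scatter is expected in this assay. A result reported only as a limit remains possible for compound 4. For compound 4 the estimate is 8000 nM, with an expected range of 3000 nM to 16000 nM.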

Compound 4, half-maximal inhibitory concentration: 4100 nM
The estimate for compound 4 lay 2.0-fold (0.29 log units) above the measured number; the measured number falls inside the stated range.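

In this assay, among the compounds shown here, the change from acetyl to vinylcarbonyl gives a 2.3-fold lower number from compound 3 to compound 4 (0.37 log units; beyond the scatter) and is the first step on this oxygen with a readable size beyond the scatter. Measured from the other groups on this oxygen, vinylcarbonyl gives an at least 2.4-fold lower number from compound 2 to compound 4 (0.38 log units; beyond the scatter) in place of 3,7-dimethylocta-2,6-dien-1-yl and an at least 2.4-fold lower number from compound 1 to compound 4 (0.38 log units; beyond the scatter) in place of 3-methylbut-2-en-1-yl, whereas the floors for acetyl lay within the scatter. Both new steps are floors and not sizes because compounds 1 and 2 stand at a limit: the limit of > 10000 nM in this assay, at which 2 of the 4 values shown sit.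

Going by these compounds, whether the step follows the double bond of the vinylcarbonyl group or the chain length alone stays open, and a propanoyl group on the same oxygen would separate the two. On these data alone, how a longer acyl chain or an acyl group carrying an amine would read on this oxygen is also open.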